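Aryl urea series: cyclohexyl ethers, tolyl variant expected

The compounds below may be only part of what the source reports. "The series", "measured", "known", "first", "only" and "open" are said of these compounds alone.

Measured so far:
- compound 1 `CSc1ccc(NC(=O)N[C@H]2CC[C@H](Oc3ccc(F)cc3)CC2)cc1`: > 20000 nM
- compound 2 `O=C(Nc1cccc(C(F)(F)F)c1)N[C@H]1CCC[C@H](Oc2ccc(C(F)(F)F)cc2)C1`: 3800 nM
- compound 3 `O=C(Nc1cccc(C(F)(F)F)c1)N[C@H]1CC[C@H](Oc2cccc(F)c2)CC1`: 2400 nM

In a functional assay on CRL2813 cells (Homo sapiens) for cytotoxicity, read by sulforhodamine B assay, with a stated time of 5 days (on this read-out lower numbers stand for stronger inhibition and higher numbers for weaker inhibition), compound 1 gives only a limit, > 20000 nM, and no number. The two trifluoromethylphenyl ureas do return numbers: compound 2 gives 3800 nM and compound 3 gives 2400 nM; these two values lie within the usual scatter of each other, so no order between them is claimed. Compound 4 `Cc1ccccc1NC(=O)N[C@H]1CC[C@H](Oc2ccc(F)cc2)CC1` is not yet measured; it differs from compound 1 by 2-methylphenyl in place of 4-(methylsulfanyl)phenyl on an amide-type nitrogen. Within the data shown here, no single step between measured compounds is available to gauge this change, and the limit for compound 1 the limit of > 20000 nM in this assay, at which 1 of the 3 values shown sits, leaves its true value open. The step expected from compound 1 to compound 4 is an at least 1.6-fold lower number from compound 1 to compound 4 (0.22 log units; that floor lies within the scatter), with a real chance that only a limit is again returned. For compound 4 the estimated value is 12000 nM, with a range from 3000 nM to 40000 nM.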

Compound 4, half-maximal inhibitory concentration: > 20000 nM
Compound 4: a limit, no number (the forecaster's own chance of this, stated with the estimate: 50%); middle value at least 1.6-fold (0.22 log units) from the limit.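

In this assay compound 4 gives > 20000 nM, a limit, as compound 1 does, and no step between the two can be read: the limit of > 20000 nM in this assay, at which 2 of the 4 values shown sit.

The compounds shown leave open where the true values of compound 1 and compound 4 lie, and whether 2-methylphenyl and 4-(methylsulfanyl)phenyl differ at all on this amide-type nitrogen.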